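The source may hold more compounds than are shown below. What is called first, only, known or untested is meant among the compounds shown, and "the series" means these compounds.

In a physicochemical assay for acid dissociation, compound 1 (`NS(=O)(=O)c1ccc(S(=O)(=O)CCCO)s1`) gives 8.32, compound 2 (`CC(=O)OCCCS(=O)(=O)c1ccc(S(N)(=O)=O)s1`) gives 8.05 and compound 3 (`COCC(=O)OCCCS(=O)(=O)c1ccc(S(N)(=O)=O)s1`) gives 8.1, which places compound 3 within the scatter of both others. Compound 4 (`NS(=O)(=O)c1ccc(S(=O)(=O)CCCCO)s1`) differs from compound 3 by hydroxymethyl in place of ((methoxymethyl)carbonyl)oxy on a saturated chain carbon, three bonds along the chain from a sulfonyl sulfur. Going by the values given here, compound 4 ends in hydroxymethyl and compound 1 also carries a free hydroxyl, so the steps that bear on this change are a number 0.22 log units lower from compound 1 to compound 3 (within the scatter) and a number 0.27 log units lower from compound 1 to compound 2 (within the scatter). The remaining step, a number 0.05 log units higher from compound 2 to compound 3 (within the scatter), shows little change between the two esters. Among the compounds with values here, no measured step covers the change in chain. The expected move is a number 0.20 log units higher from compound 3 to compound 4 (within the scatter), with nothing expected beyond the scatter. The estimate for compound 4 is 8.3, with a range of 8 to 8.6.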

Compound 4, acid dissociation constant: 8.67
For compound 4 the middle estimate is 0.37 log units below the measured one, outside the stated range (above it).
By their numbers in this assay, from the lowest: compounds 2, 3 and 1 (each within the scatter of the next); then compound 4.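

In this assay, going by these compounds alone, the ending in hydroxymethyl at this place gives the first steps that clear the scatter, a number 0.57 log units higher from compound 3 to compound 4 (beyond the scatter) and a number 0.62 log units higher from compound 2 to compound 4 (beyond the scatter) against the two esters. A free hydroxyl stands at the chain end on both sides of the remaining step, yet a number 0.35 log units higher from compound 1 to compound 4 (beyond the scatter) still appears, so the chain change alone moves this number, whereas the two esters stay within the scatter of compound 1.

Going by these compounds, whether a longer chain extends the rise, or an amine or a carboxylic acid at the chain end keeps it, stays open. Nothing shown accounts for the shift.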